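The source may hold more compounds than are shown below. What is called first, only, known or untested is meant among the compounds shown, and "the series" means these compounds.

Compound 1 `CC1=C(N2CC2)C(=O)C(CCCOC(N)=O)=C(N2CC2)C1=O` in a functional assay on L1210 cells (Mus musculus), with a stated time of 12 days (a higher number here means a more potent compound, by a factor of ten per unit of this negative logarithm, a lower number a less potent compound), gives 6.18, second highest of the three measured values. Compound 2 `CC1=C(N2CC2)C(=O)C(C2CCCCC2)=C(N2CC2)C1=O` gives 5.82, and compound 3 `CC1=C(N2CC2)C(=O)C(N2CC2)=C(N2CC2)C1=O` gives 6.77. The steps of a number 0.36 log units lower from compound 1 to compound 2 (beyond the scatter) and a number 0.59 log units higher from compound 1 to compound 3 (beyond the scatter) frame compound 1 on both sides, and a number 0.95 log units higher from compound 2 to compound 3 (beyond the scatter) spans the whole set. Compound 4 `CC1=C(N2CC2)C(=O)C(COc2ccccc2)=C(N2CC2)C1=O` differs from compound 1 by phenoxy in place of 2-(carbamoyloxy)ethyl on a saturated chain carbon bound to a double-bonded ring carbon. Among the compounds with values here, the nearest precedent is the step to compound 2, where a ring of carbon only likewise replaced a chain without a ring on the same side of the core. Because a number 0.36 log units lower from compound 1 to compound 2 (beyond the scatter) ran downward, a modest decrease is expected for compound 4, a number 0.33 log units lower from compound 1 to compound 4 (beyond the scatter). Compound 4 is therefore estimated at 5.85, with a range of 5.4 to 6.3.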

Compound 4, logarithm of the reciprocal of the active concentration, log(1/C): 5.15
For compound 4 the middle estimate is 0.70 log units above the measured one, and the stated range ends above it.
By their numbers in this assay, from the lowest: compound 4; then compound 2; then compound 1; then compound 3.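

In this assay, phenoxy in place of 2-(carbamoyloxy)ethyl on a saturated chain carbon bound to a double-bonded ring carbon gives a number 1.03 log units lower from compound 1 to compound 4 (beyond the scatter), a large fall. Both ring-bearing changes from compound 1 go downward, but this one is clearly larger than a number 0.36 log units lower from compound 1 to compound 2 (beyond the scatter), so the presence of a six-membered ring does not alone set the size of the step. Nothing available here accounts for the drop. Still open, on these data alone, is whether entry of phenoxy or loss of the carbamoyloxy end matters more. A plain propyl chain or a chain ending in an amine at this position would help separate the two.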